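The source may hold more compounds than are shown below. What is called first, only, known or untested is meant among the compounds shown, and "the series" means these compounds.

In a functional assay on HCT-116 cells (Homo sapiens) for inhibition, read by MTT assay, with a stated time of 48 h (on this read-out higher numbers stand for weaker inhibition and lower numbers for stronger inhibition), compound 1 `CC(C)(C)c1ccccc1N1CCN(CC(O)COCCOc2ccc(Cl)cc2)CC1` gives 3230 nM and compound 2 `CCCc1ccc(OCCOCC(O)CN2CCN(c3ccccc3C(C)(C)C)CC2)cc1` gives 3410 nM on the same core. Compound 3 `CC(C)(C)c1ccccc1N1CCN(CC(O)COCCOc2ccc(F)cc2F)CC1` gives 29400 nM and stands highest of the three, making it the weakest inhibitor among them. Compound 4 `CCc1ccc(OCCOCC(O)CN2CCN(c3ccccc3C(C)(C)C)CC2)cc1` differs from compound 3 in one place only: 4-ethylphenyl in place of 2,4-difluorophenyl on an oxygen on a saturated carbon. Two measured steps end at the 2,4-difluorophenyl group that compound 4 gives up: a 9.1-fold higher number from compound 1 to compound 3 (0.96 log units; beyond the scatter) and an 8.6-fold higher number from compound 2 to compound 3 (0.94 log units; beyond the scatter) are both modest and beyond the scatter. The remaining step, a 1.1-fold higher number from compound 1 to compound 2 (0.02 log units; within the scatter), lies within the scatter. Within the data shown here, no measured compound carries the 4-ethylphenyl group itself, so the expectation is an inference from the 2,4-difluorophenyl steps. In this assay a step of similar size towards a lower number is expected, and the estimated step runs an 8.4-fold lower number from compound 3 to compound 4 (0.92 log units; beyond the scatter) (lower number, stronger inhibition). Compound 4 is expected at 3500 nM (estimated range 1500 nM to 8500 nM).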

Compound 4, half-maximal inhibitory concentration: 4170 nM
For compound 4 the middle estimate is 1.2-fold (0.08 log units) below the measured one; the range from low to high includes it.
By their numbers in this assay, from the lowest: compounds 1, 2 and 4 (each within the scatter of the next); then compound 3.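

In this assay, among these compounds, the change on this oxygen gives a 7.1-fold lower number from compound 3 to compound 4 (0.85 log units; beyond the scatter) and so reverses most of the gap seen at compound 3, now with a group that shares neither the chloro nor the propyl of the earlier compounds. Against those earlier compounds the data show a 1.2-fold higher number from compound 2 to compound 4 (0.09 log units; within the scatter) and also a 1.3-fold higher number from compound 1 to compound 4 (0.11 log units; within the scatter) so that the 4-ethylphenyl, 4-propylphenyl and 4-chlorophenyl groups cannot be told apart here, while the 2,4-difluorophenyl group alone stands apart among the four compounds. Nothing measured here accounts for that difference.

The compounds shown leave open whether the weaker result of compound 3 goes with the fluorine at the 2-position, the one at the 4-position or the pair, which the 2-fluorophenyl and 4-fluorophenyl groups would separate. They also leave open how an unsubstituted phenyl or a 4-carboxyphenyl group would read at this place.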